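A Thiophene Ring in Place of a Furan Ring

The source may hold more compounds than are shown below. What is called first, only, known or untested is meant among the compounds shown, and "the series" means these compounds.

Compound 1 `Cc1cccc(Nc2nccc(-c3cc(C)oc3C)n2)c1` is the weakest of the three measured compounds: in a functional assay for inhibition, with Homo sapiens as the target (on this read-out higher numbers stand for weaker inhibition and lower numbers for stronger inhibition), compound 1 gives 28500 nM. Compound 2 `Cc1cc(C)cc(Nc2nccc(-c3cc(C)oc3C)n2)c1` gives 4100 nM, and compound 3 `Cc1cc(-c2ccnc(Nc3ccccc3)n2)c(C)o1` gives 2000 nM. The two measured steps, a 7.0-fold lower number from compound 1 to compound 2 (0.84 log units; beyond the scatter) and a 14-fold lower number from compound 1 to compound 3 (1.15 log units; beyond the scatter), both swap a methyl and a hydrogen on an aromatic carbon, leaving the five-membered ring untouched. Compound 4 `Cc1cccc(Nc2nccc(-c3ccc(C)s3)n2)c1` differs from compound 1 in that five-membered ring instead: 5-methylthiophen-2-yl in place of 2,5-dimethylfuran-3-yl on an aromatic carbon. Neither measured step bears on this change, so no step beyond the usual scatter is expected in either direction in this assay, with wide uncertainty. For compound 4 the estimated value in this assay is 20000 nM, with a range from 5000 nM to 80000 nM. That estimate corresponds to an expected step of a 1.4-fold lower number from compound 1 to compound 4 (0.15 log units; within the scatter).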

Compound 4, half-maximal inhibitory concentration: 1400 nM
The estimate for compound 4 lay 14-fold (1.15 log units) above the measured number; measured number outside the range, below it.
By their numbers in this assay, from the lowest: compounds 4 and 3 (each within the scatter of the next); then compound 2; then compound 1.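

Within this assay replacing 2,5-dimethylfuran-3-yl with 5-methylthiophen-2-yl gives a 20-fold lower number from compound 1 to compound 4 (1.31 log units; beyond the scatter) and so shows that inhibition responds strongly to this five-membered ring. The earlier steps shown here left this ring untouched, so they could not show this. No available evidence explains the effect of the swap.

On these data alone, the swap changes the hetero atom, the point of attachment and the number of methyl groups at once, so which of these matters remains unknown. As far as these compounds go, whether an amine or a carboxylic acid in place of the thiophene methyl would keep this gain also remains open.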